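Hydroxy for Nitro on Two Pyrimidine-Bearing Cores

This account rests on a few compounds, and the source may have more. Where it says the series, first, only, none or still open, it means among the compounds named here.

Measured compounds:
compound 1, `COc1ccc(N(C)c2ccnc(Cl)n2)cc1[N+](=O)[O-]`, 3780 nM
compound 2, `COc1ccc(N(C)c2ccnc(Cl)n2)cc1O`, 381 nM
compound 3, `COc1ccc(N(C)c2cc(C)nc(C)n2)cc1[N+](=O)[O-]`, 3270 nM

The study compares three measured compounds and one that is still to be measured, compound 4, `COc1ccc(N(C)c2cc(C)nc(C)n2)cc1O`. In a functional assay on A549 cells (Homo sapiens) for antiproliferative activity, read by MTT assay, with a stated time of 48 h (on this read-out higher numbers stand for weaker inhibition and lower numbers for stronger inhibition), compound 1 gives 3780 nM, and compound 2 gives 381 nM. The change between them is hydroxy in place of nitro on an aromatic carbon, and it made a step of a 9.9-fold lower number from compound 1 to compound 2 (1.00 log units; beyond the scatter). Compound 3 gives 3270 nM in this assay, and its value stands within the scatter of that of compound 1, so no order between compound 1 and compound 3 can be read from these two numbers. The difference between the core of compound 1 and the core of compound 3 is not broken down here.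

Compound 4 is to be made from compound 3 by hydroxy in place of nitro on an aromatic carbon. This is the same kind of change as that from compound 1 to compound 2: in both, the hydroxy sits ortho to a methoxy group, but in the one case it is described as meta to a group of 9 heavy atoms and in the other as meta to a large group. The same change occurs two times among these compounds, once measured and once pending.

Since compound 3 sits within the scatter of compound 1, and the change from compound 1 to compound 2 gave a 9.9-fold lower number from compound 1 to compound 2 (1.00 log units; beyond the scatter), the step from compound 3 to compound 4 is expected to be of a similar size, about an 8.2-fold lower number from compound 3 to compound 4 (0.91 log units; beyond the scatter). Compound 4 is therefore estimated at 400 nM in this assay, with a range from 150 nM to 1200 nM.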

Compound 4, half-maximal inhibitory concentration: 113 nM
Estimate against measurement, compound 4: 3.5-fold (0.55 log units) above, outside the stated range (below it).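

In this assay, hydroxy in place of nitro on an aromatic carbon again gave a lower number, with a 29-fold lower number from compound 3 to compound 4 (1.46 log units; beyond the scatter), so the direction of the change seen on the core of compound 1 also held on the core of compound 3. The size of the step did not carry over unchanged, and the step on the core of compound 3 is the larger of the two: the same change on two cores in this assay, a 9.9-fold lower number (1.00 log units; beyond the scatter) from compound 1 to compound 2 and a 29-fold lower number (1.46 log units; beyond the scatter) from compound 3 to compound 4, 2.9-fold (0.46 log units) apart, beyond the scatter of two such steps. This shows that, in this series, the direction of the change transferred between these two cores while its size depended on the core, but two pairs set no rule for any further core, and the cores differ in more than one place, so these pairs cannot show which part of the core goes with the larger step.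

The compounds shown leave open whether an amine or a carboxylic acid in place of the nitro would give numbers closer to those of the hydroxy compounds or of the nitro compounds on either core. They also leave open how the step would behave on a core carrying a single methyl group, and whether an ethoxy group in place of the methoxy group would alter it.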